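The source may hold more compounds than are shown below. What is called first, only, known or untested is meant among the compounds shown, and "the series" means these compounds.

Working notes on the series. Compound 1 `C/C=C/C(=O)N(Cc1ccc(OC)c(C)c1)c1cc(OC)c(OC)c(OC)c1`, compound 2 `C/C=C/C(=O)N(Cc1ccc(OC)c(Cl)c1)c1cc(OC)c(OC)c(OC)c1` and compound 3 `C/C=C/C(=O)N(Cc1ccc(OC)c(OC)c1)c1cc(OC)c(OC)c(OC)c1` share one core and differ only in a single group on an aromatic carbon. In a functional assay on MGC-803 cells (Homo sapiens) for inhibition, read by MTT assay, with a stated time of 48 h (on this read-out higher numbers stand for weaker inhibition and lower numbers for stronger inhibition), compound 1 gives 14500 nM, compound 2 gives 7100 nM and compound 3 gives 20100 nM. Compound 3 thus carries the highest number of the three: the gap from compound 1 is a 1.4-fold higher number from compound 1 to compound 3 (0.14 log units; within the scatter), within the scatter, while the gap from compound 2 is a 2.8-fold higher number from compound 2 to compound 3 (0.45 log units; beyond the scatter), beyond it. Compound 4 `C/C=C/C(=O)N(Cc1ccc(OC)c(F)c1)c1cc(OC)c(OC)c(OC)c1` has not yet been measured. It differs from compound 3 in one place: fluoro in place of methoxy on an aromatic carbon. Among the compounds with values here, two measured steps bear on this change. The exchange of methyl for methoxy, a 1.4-fold higher number from compound 1 to compound 3 (0.14 log units; within the scatter), was not resolved from the scatter; the exchange of chloro for methoxy, a 2.8-fold higher number from compound 2 to compound 3 (0.45 log units; beyond the scatter), was modest and raised the number. Within the data shown here, compound 4 puts fluoro where compound 3 carries methoxy, which is the direction of compound 2 rather than compound 1, and no measured step involves fluoro itself. For compound 4 in this assay a modest fall in the number is therefore expected, with the chloro case of compound 2 at 7100 nM as the nearest measured point of reference. The expected step is a 2.0-fold lower number from compound 3 to compound 4 (0.30 log units; within the scatter). Compound 4 is estimated at 10000 nM, with a range from 4500 nM to 22000 nM.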

Compound 4, half-maximal inhibitory concentration: 1650 nM
Compound 4: middle estimate off by 6.1-fold (0.78 log units), on the high side, outside the stated range (below it).
By their numbers in this assay, from the lowest: compound 4; then compound 2; then compounds 1 and 3 (each within the scatter of the next).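

Fluoro at this place, ortho to a methoxy group, gives the lowest number of the series in this assay, with every step to it beyond the scatter: a 12-fold lower number from compound 3 to compound 4 (1.09 log units; beyond the scatter), a 4.3-fold lower number from compound 2 to compound 4 (0.63 log units; beyond the scatter) and an 8.8-fold lower number from compound 1 to compound 4 (0.94 log units; beyond the scatter). The first of these is large and exceeds the widest gap seen among the earlier groups, a 2.8-fold higher number from compound 2 to compound 3 (0.45 log units; beyond the scatter), so this position tolerates a far wider spread of numbers than the methyl, chloro and methoxy compounds showed. Within the data shown here, both halogen compounds, compound 2 and compound 4, now carry lower numbers than compound 1 and compound 3, with no compound against that split, yet fluoro and chloro are clearly not interchangeable here. Nothing shown explains why fluoro stands apart from chloro or from methoxy at this position.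

Whether the low number is particular to fluoro stays open, since bromo, hydroxyl, amino and trifluoromethyl at this place are not among the compounds shown. Also open, as far as these compounds go, is whether the fall on exchanging methoxy for fluoro persists when the neighbouring methoxy group gives way to an ethoxy group or a hydroxyl.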